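A few compounds are considered here, and "the series" means these few. Any claim that something is new, unique, unknown or untested is made for them only; others in the source may bear on it.

Among the measured compounds shown here, compound 2 `O=[N+]([O-])c1ccc(-c2nc3cc(C(F)(F)F)ccc3[nH]2)cc1` is the only compound with a plain number in an ADME assay on BHK cells (Mesocricetus auratus) for cytotoxicity, read by MTT assay, with a stated time of 96 h (a higher number here means that more compound is tolerated, a lower number that less compound is tolerated), where compound 2 gives 18000 nM. Compound 1 `O=C(O)CCC(=O)Nc1ccc(-c2nc3cc(C(F)(F)F)ccc3[nH]2)cc1` gives in this assay only a limit, > 100000 nM. For the measured compounds named here, the single measured step, an at least 5.5-fold lower number from compound 1 to compound 2 (0.74 log units; beyond the scatter), starts from the limit of > 100000 nM in this assay, at which 1 of the 2 values shown sits, and so is itself only a bound. Compound 3 `COc1ccc(-c2nc3cc(C(F)(F)F)ccc3[nH]2)cc1` differs from compound 2 by methoxy in place of nitro on an aromatic carbon. That change resembles the measured step only in touching a nitro group, so it gives little guide. A step of a 1.7-fold higher number from compound 2 to compound 3 (0.22 log units; within the scatter) is expected, at most modest. Compound 3 is estimated at 30000 nM, between 10000 nM and 100000 nM.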

Compound 3, half-maximal cytotoxic concentration: > 100000 nM
Compound 3: no number, only a limit; the forecaster's own chance of this, stated with the estimate: 25%; middle value at least 3.3-fold (0.52 log units) away from the limit.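

Methoxy in place of nitro on the aromatic carbon para to a large group gives an at least 5.5-fold higher number from compound 2 to compound 3 (0.74 log units; beyond the scatter) in this assay. The lower number at this position now stands with nitro alone, since neither of the other two groups shown gives a plain number. Compound 3 joins compound 1 at a limit of the assay, and the step between them cannot be read: the limit of > 100000 nM in this assay, at which 2 of the 3 values shown sit.

From the compounds shown here alone, it remains open whether an amine, a chlorine or a plain hydrogen at this position would give a plain number or stay at the limit. Going by these compounds, how far compound 3 and compound 1 lie from each other also remains open.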